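The compounds below may be only part of what the source reports. "The series", "measured", "known", "first", "only" and "open" are said of these compounds alone.

Measured compounds:
- compound 1, `CC(C)(C)OC(=O)N1CCC(Oc2ncnc3c2CCN3c2ccc(S(C)(=O)=O)cc2F)CC1`: 20 nM
- compound 2, `CC(C)COC(=O)N1CCC(Oc2ncnc3c2CCN3c2ccc(S(C)(=O)=O)cc2F)CC1`: 25.1 nM
- compound 3, `CSC(=O)N1CCC(Oc2ncnc3c2CCN3c2ccc(S(C)(=O)=O)cc2F)CC1`: 251 nM

In a functional assay on CHO-K1 cells for agonist activity at Glucose-dependent insulinotropic receptor (Homo sapiens), read by a luciferase reporter, with a stated time of 5 h (a lower number here means that less compound is needed, a higher number that more compound is needed for the effect), compound 3 gives the highest of the three numbers. The two compounds bearing a tert-butoxy or isobutoxy group on the carbonyl carbon sit close together, as a 1.3-fold higher number from compound 1 to compound 2 (0.10 log units; within the scatter) shows, while the exchange for methylsulfanyl moves the number markedly: a 13-fold higher number from compound 1 to compound 3 (1.10 log units; beyond the scatter) and a 10-fold higher number from compound 2 to compound 3 (1.00 log units; beyond the scatter).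

Compound 4, `CCS(=O)(=O)N1CCC(Oc2ncnc3c2CCN3c2ccc(S(C)(=O)=O)cc2F)CC1`, takes the next step from compound 3: ethylsulfonyl in place of (methylsulfanyl)carbonyl on an amine nitrogen in a ring. Among the measured compounds shown here, no measured pair tests an ethylsulfonyl group, so the measured steps bear on it only indirectly. They show that the group on the ring nitrogen of the shared core matters, and that the (methylsulfanyl)carbonyl variant of compound 3 is the weakest point of the set. On that footing compound 4 is expected to return toward the range of compounds 1 and 2 rather than to fall further, and the estimated step is a 2.1-fold lower number from compound 3 to compound 4 (0.32 log units; beyond the scatter). The expected value for compound 4 in this assay is 120 nM, with a range from 30 nM to 500 nM.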

Compound 4, half-maximal effective concentration: 1580 nM
For compound 4 the middle estimate is 13-fold (1.12 log units) below the measured one; the whole stated range lies below it.
By their numbers in this assay, from the lowest: compounds 1 and 2 (each within the scatter of the next); then compound 3; then compound 4.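

In this assay, among the compounds shown here, ethylsulfonyl on the amine nitrogen in a ring gives a number beyond even the highest of the earlier compounds, with a 6.3-fold higher number from compound 3 to compound 4 (0.80 log units; beyond the scatter). The loss is greater against the two alkoxycarbonyl groups, with a 63-fold higher number from compound 2 to compound 4 (1.80 log units; beyond the scatter) and a 79-fold higher number from compound 1 to compound 4 (1.90 log units; beyond the scatter), so compound 4 is the weakest of the four and all three carbonyl-linked groups at this position outperform this sulfonyl-linked one. The data shown offer no measurement that explains this change.

The compounds shown do not separate the effect of the sulfonyl link from that of the ethyl group on it, as the change replaces both together. On these data alone, it also remains open how a longer chain or a tert-butyl group on the sulfonyl would read, or how an amide or urea carbonyl would compare.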